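Guanidine series: changing the side chain of compound 3

The source may report more compounds than this note shows. Statements on the series, on what has been measured and on what is new or still open speak of the compounds shown alone.

In a functional assay on MCF7 cells (Homo sapiens) for inhibition, read by fluorescence, with a stated time of 72 h (on this read-out lower numbers stand for stronger inhibition and higher numbers for weaker inhibition), compound 1 `CC(C)n1cnc2c(NC(=N)N)nc(N)nc21` gives 97200 nM as a plain number. Compound 2 `N=C(N)Nc1nc(N)nc2c1ncn2CCN` reads > 100000 nM and that is a limit of the assay, not a number. Going by the values given here, compound 3 `CC(C)n1cnc2c(NC(=N)N)nc(NCCCCCCO)nc21` gives 5200 nM and holds the lower of the two true numbers so far.

The next change leads to compound 4 `CC(C)[C@@H](N)COc1nc(NC(=N)N)c2ncn(C(C)C)c2n1` with 2-amino-3-methylbutoxy in place of (6-hydroxyhexyl)amino on an aromatic carbon between two ring nitrogen atoms (2-amino-3-methylbutoxy in place of (6-hydroxyhexyl)amino on an aromatic carbon). The step of an at least 1.0-fold higher number from compound 1 to compound 2 (0.01 log units; that floor lies within the scatter) sits on an aromatic nitrogen and does not bear on this change. The relevant one is a 19-fold lower number from compound 1 to compound 3 (1.27 log units; beyond the scatter) with 6-hydroxyhexyl in place of hydrogen on a nitrogen on an aromatic ring. Most of that gain is expected to persist in compound 4, which also carries a chain with no ring here, although no measured pair tests the new group. The estimated step of a 1.7-fold higher number from compound 3 to compound 4 (0.24 log units; within the scatter) leans to a higher number, and no clear move beyond the scatter is expected. Compound 4 is estimated at 9000 nM (expected range 2000 nM to 40000 nM) in this assay pending measurement.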

Compound 4, half-maximal inhibitory concentration: 79400 nM
For compound 4 the middle estimate is 8.8-fold (0.95 log units) below the measured one; measured number outside the range, above it.
By their numbers in this assay, from the lowest: compound 3; then compounds 4 and 1 (each within the scatter of the next). At a limit, above all of these: compound 2.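

In this assay the aromatic carbon between two ring nitrogen atoms proves sensitive to which chain without a ring it carries: 2-amino-3-methylbutoxy in place of (6-hydroxyhexyl)amino gives a 15-fold higher number from compound 3 to compound 4 (1.18 log units; beyond the scatter) and so gives up the gain seen with compound 3. Against amino at the same carbon, the same group gives a 1.2-fold lower number from compound 1 to compound 4 (0.09 log units; within the scatter) and thus no clear change, so a chain at this carbon does not by itself lower the number. Nothing measured here accounts for this loss.

From the compounds shown here alone, whether the gain rests on the linking nitrogen, the terminal hydroxyl or the length of the chain stays open. A hexylamino group without the hydroxyl, or a 6-hydroxyhexyloxy group with oxygen as the link, would separate these.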